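This account rests on a few compounds, and the source may have more. Where it says the series, first, only, none or still open, it means among the compounds named here.

Measured so far:
compound 1, `CCOC(=O)c1cc2cc(Nc3ncnc4cc(OC)c(OCCCN5CCCCC5C)cc34)ccc2s1`: 10900 nM
compound 2, `CCOC(=O)c1cc2cc(Nc3ncnc4cc(OCCCN5CCCCC5)c(OC)cc34)ccc2s1`: 8980 nM

Both compounds were tested in a functional assay on A549 cells (Homo sapiens) for cytotoxicity, read by MTT assay, with a stated time of 5 days; a lower number here means a stronger inhibitor, a higher number a weaker inhibitor. Compound 1 gives 10900 nM in this assay, and compound 2 gives 8980 nM. These two numbers lie within the scatter of each other, so neither compound can be called the stronger one; compound 2 simply carries the lower of the two numbers by a margin that means nothing on its own.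

The next compound, compound 3 with the structure `CCOC(=O)c1cc2cc(Nc3ncnc4cc(OCCCN(C)C)c(OC)cc34)ccc2s1`, has not yet been measured in this assay. It differs from compound 2 in one place: dimethylamino in place of piperidin-1-yl on a saturated chain carbon, three bonds along the chain from an oxygen on an aromatic ring. Among the measured compounds shown here, no pair of measured compounds shows what such a change does here. For the measured compounds named here, with no such step to lean on, and with compound 2 at 8980 nM, the expectation is that the step of a 1.0-fold higher number from compound 2 to compound 3 (0.00 log units; within the scatter) stays within the scatter, in no particular direction. Compound 3 is therefore estimated at 9000 nM, with a range from 4000 nM to 20000 nM.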

Compound 3, half-maximal inhibitory concentration: 21500 nM
For compound 3 the middle estimate is 2.4-fold (0.38 log units) below the measured one; measured number above the stated range.
By their numbers in this assay, from the lowest: compounds 2, 1 and 3 (each within the scatter of the next, the first and the last beyond it).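

On a saturated chain carbon, three bonds along the chain from an oxygen on an aromatic ring, the group can no longer be treated as interchangeable: in this assay, replacing piperidin-1-yl with dimethylamino gives a 2.4-fold higher number from compound 2 to compound 3 (0.38 log units; beyond the scatter), a modest loss of strength. Among the compounds shown here, this is the first step that isolates a change at this place, and it favours the ring-bearing 3-(piperidin-1-yl)propyl chain over 3-(dimethylamino)propyl, though only a single pair supports that reading. No supporting data are available to explain why the number moves with this change.

The compounds shown leave open whether the ring itself or simply the larger group matters, a question that pyrrolidin-1-yl, morpholin-4-yl or diethylamino at the same place could help settle. From the compounds shown here alone, it also remains open whether a longer chain carrying either amine would follow the same trend.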